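The source may hold more compounds than are shown below. What is called first, only, known or untested is meant among the compounds shown, and "the series" means these compounds.

Compound 1 `C=CC(=O)c1ccc(CCC)cc1` — 100000 nM
Compound 2 `C=CC(=O)c1ccc(CCCCC)cc1` — 33900 nM

In an in vitro assay on BL21-DE3 cells for displacement of a labelled ligand from thyroid hormone receptor beta (Homo sapiens), read by fluorescence polarization (on this read-out higher numbers stand for weaker inhibition and lower numbers for stronger inhibition), compound 2 gives 33900 nM, the lower of the two numbers recorded; compound 1 gives 100000 nM. Among the measured compounds shown here, the only step measured so far, a 2.9-fold lower number from compound 1 to compound 2 (0.47 log units; beyond the scatter), describes lengthening of the chain and was modest.

Compound 3 `C=CC(=O)c1ccc(CC(C)(C)C)cc1` has not yet been tested. It differs from compound 2 by tert-butyl in place of butyl on a saturated chain carbon bound to an aromatic carbon. For the measured compounds named here, no measured step concerns a rearrangement of this kind: the single step from compound 1 to compound 2 changes the length of the chain, not its branching, so it bears on the new step only indirectly, and nothing here shows what redistributing the same carbons does. Compound 3 is therefore expected to land close to compound 2, with a step of a 1.2-fold higher number from compound 2 to compound 3 (0.07 log units; within the scatter) that need not exceed the scatter. The estimate for compound 3 is 40000 nM, within 15000 nM to 100000 nM.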

Compound 3, half-maximal inhibitory concentration: 43500 nM
Compound 3: middle estimate off by 1.1-fold (0.04 log units), on the low side; low and high end bracket the measured number.
By their numbers in this assay, from the lowest: compounds 2 and 3 (each within the scatter of the next); then compound 1.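

In this assay, rearranging the same carbons, with tert-butyl in place of butyl on a saturated chain carbon bound to an aromatic carbon, gives a 1.3-fold higher number from compound 2 to compound 3 (0.11 log units; within the scatter), so the branched and straight chains cannot be told apart at this position. The branched chain still differs from the shorter chain, with a 2.3-fold lower number from compound 1 to compound 3 (0.36 log units; beyond the scatter), so the lower number seen on lengthening the chain is not confined to the straight form. No evidence is available to explain this result.

The compounds shown leave open whether a longer chain, such as octyl, or a ring, such as cyclohexyl, would lower the number further at this place. They also leave open how an amine or a carboxylic acid on the chain would read out.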